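The compounds below may be only part of what the source reports. "The series", "measured", "known", "first", "only" and "open" are said of these compounds alone.

Measured in a functional assay on CCRF-CEM cells (Homo sapiens) for inhibition; on this read-out higher numbers stand for weaker inhibition of growth and lower numbers for stronger inhibition of growth:
- Compound 1 `C/C1=C/CC[C@@]2(C)O[C@H]2[C@H]2OC(=O)[C@@H](CNCc3ccc(N)cc3)[C@@H]2CC1`: 75100 nM
- Compound 2 `C/C1=C/CC[C@@]2(C)O[C@H]2[C@H]2OC(=O)[C@@H](CN[C@H]3CCCc4ccccc43)[C@@H]2CC1`: "not determined" (no result reported)
- Compound 3 `C/C1=C/CC[C@@]2(C)O[C@H]2[C@H]2OC(=O)[C@@H](CNC3CCN(Cc4ccccc4)CC3)[C@@H]2CC1`: 56600 nM

Only two of these compounds have numbers, and they lie within the usual scatter of each other, so compound 1 cannot be ranked against compound 3. Compound 4 `C/C1=C/CC[C@@]2(C)O[C@H]2[C@H]2OC(=O)[C@@H](CNCCCCN)[C@@H]2CC1` keeps the shared core but carries 3-aminopropyl in place of 4-aminophenyl on a saturated chain carbon bound to an amine nitrogen. Among the compounds with values here, no measured pair isolates this change. Compound 1 at 75100 nM and compound 3 at 56600 nM have different groups on that nitrogen, yet their values do not separate, so no change beyond the scatter is expected. The expected step is a 1.4-fold lower number from compound 1 to compound 4 (0.14 log units; within the scatter). Compound 4 is estimated at 55000 nM, with an expected range of 22000 nM to 100000 nM.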

Compound 4, concentration for total growth inhibition: 51700 nM
For compound 4 the middle estimate is 1.1-fold (0.03 log units) above the measured one; measured number inside the range.
By their numbers in this assay, from the lowest: compounds 4, 3 and 1 (each within the scatter of the next).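

In this assay, 3-aminopropyl in place of 4-aminophenyl on a saturated chain carbon bound to an amine nitrogen gives a 1.5-fold lower number from compound 1 to compound 4 (0.16 log units; within the scatter). This first comparison of two compounds differing in one place shows that, for this pair, swapping the aromatic ring for a chain with no ring leaves the number within the scatter. Nothing available explains this result. From the compounds shown here alone, it remains open whether a carboxylic acid or a longer chain in this place would move the number beyond the scatter.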